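The source may report more compounds than this note shows. Statements on the series, on what has been measured and on what is new or still open speak of the compounds shown alone.

In a functional assay on A-375 cells (Homo sapiens) for cytotoxicity, read by MTT assay (on this read-out higher numbers stand for weaker inhibition and lower numbers for stronger inhibition), compound 3 `O=C(NCCNc1nccc(-c2c(-c3cccc(F)c3)nc3sccn23)n1)c1ccc(Cl)cc1` gives 2570 nM. Compound 1 `O=S(=O)(NCCCNc1nccc(-c2c(-c3cccc(F)c3)nc3sccn23)n1)c1ccc(C(F)(F)F)cc1` gives 4090 nM, a number within the scatter of compound 3, while compound 2 `O=S(=O)(NCCCNc1nccc(-c2c(-c3cccc(F)c3)nc3sccn23)n1)c1ccc(Cl)cc1` gives 5900 nM, which lies beyond the scatter from compound 3. The next step is to compound 4 `O=S(=O)(NCCCNc1nccc(-c2c(-c3cccc(F)c3)nc3sccn23)n1)c1ccccc1`: ((phenylsulfonyl)amino)methyl in place of ((4-chlorophenyl)carbonyl)amino on a saturated chain carbon, two bonds along the chain from a nitrogen on an aromatic ring. Among the compounds with values here, two measured steps bear on it. a 2.3-fold lower number from compound 2 to compound 3 (0.36 log units; beyond the scatter) runs in the reverse sense of the carbonyl-to-sulfonyl part of this change, and a 1.4-fold higher number from compound 1 to compound 2 (0.16 log units; within the scatter) suggests that altering the substituent on the outer aromatic ring shifts the number little. Compound 4 is therefore expected to give a modestly higher number than compound 3, a 2.1-fold higher number from compound 3 to compound 4 (0.33 log units; beyond the scatter). The estimate for compound 4 is 5500 nM, within a range from 2500 nM to 12000 nM.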

Compound 4, half-maximal inhibitory concentration: 6600 nM
Estimate against measurement, compound 4: 1.2-fold (0.08 log units) below; the range from low to high includes it.
By their numbers in this assay, from the lowest: compounds 3, 1, 2 and 4 (each within the scatter of the next, the first and the last beyond it).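

In this assay the higher number on the sulfonyl side holds without any substituent on the outer ring, with a 2.6-fold higher number from compound 3 to compound 4 (0.41 log units; beyond the scatter). That ring position adds little among these sulfonamides: hydrogen in place of chloro gives a 1.1-fold higher number from compound 2 to compound 4 (0.05 log units; within the scatter), and hydrogen in place of trifluoromethyl gives a 1.6-fold higher number from compound 1 to compound 4 (0.21 log units; within the scatter). No measurement shown explains why the ((4-chlorophenyl)carbonyl)amino compound gives the lowest number.

Still open, from the compounds shown here alone, is how a methoxy group on the outer ring, or a longer chain, would move the number.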